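This account rests on a few compounds, and the source may have more. Where it says the series, first, only, none or still open, it means among the compounds named here.

Three compounds of the series have numbers in a functional assay on UACC-257 cells (Homo sapiens) for inhibition, read by sulforhodamine B assay, with a stated time of 48 h, tested at 10 uM (on this read-out higher numbers stand for more inhibition of growth at the one concentration tested and lower numbers for less inhibition of growth), so far. Compound 1 `C/C(=N\O)c1ccc(NC(=O)Cn2nc(-c3ccc(Cl)cc3)nc2N)cc1` gives 27.8% in this assay. Compound 2 `COc1cc(-c2nc(N)n(CC(=O)Nc3ccc(/C(C)=N\O)cc3)n2)cc(OC)c1OC` gives 36.3%. Compound 3 `C/C(=N/O)c1ccc(NC(=O)Cn2nc(-c3ccccc3)nc2N)cc1` gives 34%. On these three numbers compound 3 stands second highest, with compound 2 nearest and compound 1 furthest away, and both gaps lie within the scatter of repeated measurements, so the three compounds are not separated from each other by this read-out.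

Compound 4 `C/C(=N/O)c1ccc(NC(=O)Cn2nc(C(F)(F)F)nc2N)cc1` is not yet measured. It differs from compound 3 in one place: trifluoromethyl in place of phenyl on an aromatic carbon. Going by the values given here, no step between two measured compounds shows what this kind of change does, so the expectation rests only on the narrow band in which compounds 1, 2 and 3 sit.

The step from compound 3 to compound 4 is expected to be small and downward, a number 9 percentage points lower from compound 3 to compound 4 (within the scatter), most likely not beyond the scatter. Compound 4 is therefore estimated at 25% in this assay, with a range from 8% to 42%.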

Compound 4, percent growth inhibition at one concentration: 25.6%
Estimate against measurement, compound 4: 0.6 percentage points below, within the range that was stated.
By their numbers in this assay, from the lowest: compounds 4, 1, 3 and 2 (each within the scatter of the next, the first and the last beyond it).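

In this assay, going by these compounds alone, trifluoromethyl in place of phenyl on the aromatic carbon of the five-membered ring gives a number 8.4 percentage points lower from compound 3 to compound 4 (within the scatter) as the first step that can be read at this position. The six-membered aromatic ring at this carbon is therefore not needed to keep the number within the scatter of compound 3, and a group with no ring and fewer heavy atoms serves here in this one pair. No measured finding is at hand that would explain the step.

Going by these compounds, whether an amine, a carboxylic acid or a longer alkyl chain on this carbon would also stay within the scatter of compound 3 remains open. On these data alone, it is equally open whether the same change would give a step of this size from compound 1 or compound 2.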